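The source may report more compounds than this note shows. Statements on the series, on what has been measured and on what is new or still open speak of the compounds shown alone.

Compound 1 `Cn1ncc(Cl)c1-c1cc(C(=O)N[C@@H]2CN[C@H](CCN3CCC(O)CC3)C[C@H]2c2ccc(Cl)c(Cl)c2)oc1Cl` is the reference point of this pair. In a functional assay on LNCaP cells (Homo sapiens) for antiproliferative activity (on this read-out higher numbers stand for weaker inhibition and lower numbers for stronger inhibition), compound 1 gives 1140 nM, the highest of the two numbers in hand; its nearest neighbour is compound 2 `Cn1ncc(Cl)c1-c1cc(C(=O)N[C@@H]2CN[C@H](CC(=O)NCC(O)CO)C[C@H]2c2ccc(Cl)c(Cl)c2)oc1Cl`, which in this assay gives 660 nM, so that the step of a 1.7-fold lower number from compound 1 to compound 2 (0.24 log units; within the scatter) stays inside the scatter. Compound 3 `Cn1ncc(Cl)c1-c1cc(C(=O)N[C@@H]2CN[C@H](CCO)C[C@H]2c2ccc(Cl)c(Cl)c2)oc1Cl` is not yet measured. It differs from compound 1 by hydroxy in place of 4-hydroxypiperidin-1-yl on a saturated chain carbon, two bonds along the chain from a saturated ring carbon. Among the compounds with values here, the only measured step that bears on this change is the one from compound 1 to compound 2, which also exchanges the terminal part of the same chain and came out as a 1.7-fold lower number from compound 1 to compound 2 (0.24 log units; within the scatter), within the scatter. The end of this chain therefore appears tolerant to exchange, at least on these two compounds, and the hydroxy of compound 3 is a further variation at the same place. No step beyond the scatter is expected for compound 3, and its number in this assay is estimated at 900 nM, with a range from 400 nM to 2500 nM. The step of a 1.3-fold lower number from compound 1 to compound 3 (0.10 log units; within the scatter) is thus expected to remain within the scatter.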

Compound 3, half-maximal inhibitory concentration: 160 nM
Compound 3: middle estimate off by 5.6-fold (0.75 log units), on the high side, and the stated range ends above it.
By their numbers in this assay, from the lowest: compound 3; then compounds 2 and 1 (each within the scatter of the next).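

In this assay, within the data shown here, the end of this chain proves less tolerant than the first pair suggested: hydroxy in place of 4-hydroxypiperidin-1-yl gives a 7.1-fold lower number from compound 1 to compound 3 (0.85 log units; beyond the scatter) and is the first step at this position to pass the scatter. Hydroxymethyl in place of (2,3-dihydroxypropyl)carbamoyl, read one bond further in along the same chain, gives a 4.1-fold lower number from compound 2 to compound 3 (0.62 log units; beyond the scatter), so compound 3 stands apart from both compound 1 and compound 2, whose two larger chain ends remain within the scatter of each other and give no separation on their own. No measurement in hand accounts for this difference.

The three compounds do not separate the presence of the terminal hydroxy from the removal of the larger chain ends, and a methoxy or a plain ethyl chain at the same place would address that point. How far the lower number extends along this chain also remains open, as the shown series holds no primary amine, no carboxylic acid and no longer chain ending in hydroxy on this saturated ring carbon.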